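A few compounds are considered here, and "the series" means these few. Any claim that something is new, unique, unknown or untested is made for them only; others in the source may bear on it.

Three compounds of this series have so far been examined in an assay on HEK293 cells for inhibition of Voltage-dependent T-type calcium channel subunit alpha-1G (Homo sapiens), read by fluorescence, tested at 10 uM; a lower number here means less inhibition, a higher number more inhibition at the concentration tested (going by the name of the read-out). In this assay compound 1 `CCCc1nc(-c2ccccc2)c(CNCCN2CCN(c3ccccc3OC)CC2)o1` gives 39.7%, the lowest of the three numbers. Compound 3 `CCCc1nc(-c2ccccc2)c(CNCCCN2CCN(c3ccc(OC)cc3)CC2)o1` gives 42.1% in this assay, a number only slightly higher than that of compound 1 and within the scatter of the method, so the two cannot be told apart. Compound 2 `Cc1nc(-c2ccccc2)c(CNCCN2CCN(C(c3ccccc3)c3ccccc3)CC2)o1` gives 57.3% in this assay, which stands beyond the scatter above compound 1. No pair among these differs in a single place, so no step between measured compounds can be read off.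

Compound 4 `CCCc1nc(-c2ccccc2)c(CNCCN2CCN(c3ccc(C(F)(F)F)cc3)CC2)o1` has not yet been measured. It differs from compound 1 in one place: 4-(trifluoromethyl)phenyl in place of 2-methoxyphenyl on an amine nitrogen in a ring. Within the data shown here, with no measured pair to lean on, the size of this step in this assay is uncertain; a modest rise is expected, but one that stays within the scatter, so the step from compound 1 to compound 4 is estimated as a number 5.3 percentage points higher from compound 1 to compound 4 (within the scatter). Compound 4 is accordingly expected to give about 45% in this assay, within a range from 25% to 65%.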

Compound 4, a percentage reported as inhibition, at one concentration (the size of the read-out at that concentration, not a potency): 58.7%
For compound 4 the middle estimate is 13.7 percentage points below the measured one; low and high end bracket the measured number.
By their numbers in this assay, from the lowest: compounds 1 and 3 (each within the scatter of the next); then compounds 2 and 4 (each within the scatter of the next).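

In this assay, among these compounds, placing 4-(trifluoromethyl)phenyl in place of 2-methoxyphenyl on an amine nitrogen in a ring gives a number 19 percentage points higher from compound 1 to compound 4 (beyond the scatter), the first change at a single place that can be read. Among the compounds shown here, it shows that the read-out responds to the aryl group at this position, something the earlier compounds, none of which differ in one place only, could not show. Nothing at hand explains this rise.

For the compounds shown here, the single step changes both the group leaving and the group entering, so it remains open whether the loss of methoxy or the gain of trifluoromethyl carries it. Also open, on these data alone, is how an unsubstituted phenyl or a phenyl bearing chlorine or a nitrile would behave at this position, and whether the step would hold with a longer chain linking the two amine nitrogens.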